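The source may hold more compounds than are shown below. What is called first, only, known or untested is meant among the compounds shown, and "the series" means these compounds.

Measured in a functional assay on NCI-H1975 cells (Homo sapiens) for antiproliferative activity, read by MTT assay, with a stated time of 72 h; a higher number here means a weaker inhibitor, a lower number a stronger inhibitor:
compound 1 `O=C(Nc1cc(Nc2ccc(Cl)cc2)ncn1)c1ccc(F)cc1`: 17600 nM
compound 2 `COc1ccc(OC)c(Nc2cc(Nc3ccc(F)cc3)ncn2)c1`: > 30000 nM (a limit of the assay, not a number)

Compound 2 has no true number, only a limit. It stands at the limit of > 30000 nM in this assay, at which 1 of the 2 values shown sits. Among the measured compounds shown here, the only true number so far belongs to compound 1, at 17600 nM, and both compounds read as weak inhibitors.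

The next compound is compound 3 `COc1cccc(Nc2cc(Nc3cc(OC)ccc3OC)ncn2)c1`, which keeps the dimethoxy-bearing side of compound 2 and changes the other. The change is 3-methoxyphenyl in place of 4-fluorophenyl on a nitrogen on an aromatic ring, with 3-methoxyphenyl in place of 4-fluorophenyl on a nitrogen on an aromatic ring. For the measured compounds named here, no measured pair shows a change of this kind, so nothing sizes it directly. In this assay, on these data alone, no shift beyond the scatter is expected, and the direction stays open. The expected step is an at least 1.0-fold lower number from compound 2 to compound 3 (0.02 log units; that floor lies within the scatter). This expectation rests on compound 2 at > 30000 nM as its nearest neighbour. A reading that is again only a limit is quite likely. For compound 3 the estimated value is 28000 nM, with an expected range of 12000 nM to 60000 nM.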

Compound 3, half-maximal inhibitory concentration: 890 nM
Compound 3: the middle estimate sits 31-fold (1.50 log units) above what was measured, outside the stated range (below it).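

In this assay, 3-methoxyphenyl in place of 4-fluorophenyl on a nitrogen on an aromatic ring gives an at least 33-fold lower number from compound 2 to compound 3 (1.52 log units; beyond the scatter). This position is therefore not indifferent to what it carries, and with the dimethoxy-bearing side held constant, this one change is enough to move the reading clear of the scatter. The entering group counts a hydrogen-bond acceptor where the leaving group counts none, but a single pair cannot tie the step to that count. The true size of the step stays unknown, as compound 2 has only a limit of the assay and not a number: the limit of > 30000 nM in this assay, at which 1 of the 3 values shown sits.

The compounds shown do not separate the arrival of the methoxy group from the loss of the fluorine, and they do not show whether the position of the methoxy group on the ring matters. Also open, on these data alone, is whether an amine or a longer alkoxy chain at the same place on that phenyl ring would keep, extend or lose the gain seen in compound 3.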